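The source may report more compounds than this note shows. Statements on the series, on what has been measured and on what is new or still open speak of the compounds shown alone.

The compounds here share one core and differ only in one substituent: compound 1 is `CCOC(=O)c1cc(COc2ccnc3cc(C(F)(F)F)ccc23)on1`, compound 2 is `CCOC(=O)c1cc(COc2ccnc3cc(Cl)ccc23)on1`, compound 3 is `CCOC(=O)c1cc(COc2ccnc3ccccc23)on1` and compound 4 is `CCOC(=O)c1cc(COc2ccnc3c(C(F)(F)F)cccc23)on1`. They are compared in an ADME assay on Vero cells (Chlorocebus sabaeus) for cytotoxicity, with a stated time of 72 h; on this read-out higher numbers stand for weaker inhibition and lower numbers for stronger inhibition. Compound 3 gives > 128000 nM, which is a limit and not a number. Compound 2 gives > 128000 nM, which is also a limit. Compound 1 also carries a trifluoromethyl group but offers no guide, since compound 1 has the entry "not determined" (no result reported).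

Compound 4 takes trifluoromethyl in place of hydrogen on an aromatic carbon of compound 3 (trifluoromethyl in place of hydrogen on an aromatic carbon). The new group stands ortho to a fused ring. Among the measured compounds shown here, the one measured step that bears on this change is a step that the two limits leave unreadable from compound 2 to compound 3, where hydrogen replaces chloro. Beyond that, the series offers only (the limit of > 128000 nM in this assay, at which 2 of the 3 values shown sit).

No measured size can therefore be carried over. No step beyond the usual scatter is expected in this assay, and no direction is favoured, the estimated step being a number no higher from compound 3 to compound 4 (the limit leaves the size open). This expectation rests on compound 3, whose > 128000 nM is a limit. For compound 4 the estimate is 128000 nM, with an expected range from 50000 nM to 200000 nM, and the result may well be reported only as a limit.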

Compound 4, half-maximal inhibitory concentration: > 128000 nM
Compound 4: a limit, no number; the forecaster's own chance of this, stated with the estimate: 80%; the middle value lies on the limit itself.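

In this assay compound 4 gives > 128000 nM, which is a limit and not a number. Among the compounds shown here, compound 3 also stands only as a limit, so no step between compound 3 and compound 4 can be read. The compounds shown leave open whether any of these substituents on the shared core changes this read-out at all, and the series offers only this: the limit of > 128000 nM in this assay, at which 3 of the 4 values shown sit.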